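A few compounds are considered here, and "the series" means these few. Any claim that something is new, unique, unknown or untested is made for them only; others in the source may bear on it.

In an ADME assay on HEK-293T cells (Homo sapiens) for inhibition, read by CCK-8 assay, with a stated time of 48 h, tested at 20 uM (on this read-out lower numbers stand for less inhibition of growth and higher numbers for more inhibition of growth at the one concentration tested), compound 1 (`Cc1ccc(S(=O)(=O)Oc2ccccc2/C=C(\C#N)C(=O)Nc2nnc(C)s2)cc1`) gives 35% as the second highest of three numbers. Compound 2 (`N#C/C(=C\c1cccc(OS(=O)(=O)c2cccs2)c1)C(=O)Nc1nnc(-c2cccs2)s1`) stands higher at 50% and compound 3 (`COc1ccc(S(=O)(=O)Oc2ccccc2/C=C(\C#N)C(=O)Nc2nnc(Cc3ccc(F)cc3)s2)cc1`) lower at 20% with both gaps beyond the scatter. Compound 4 (`Cc1ccc(S(=O)(=O)Oc2ccccc2/C=C(\C#N)C(=O)Nc2nnc(Cc3cccc(F)c3)s2)cc1`) departs from compound 1 by one change (3-fluorophenyl in place of hydrogen on a saturated chain carbon bound to an aromatic carbon) in which 3-fluorophenyl takes the place of hydrogen on a saturated chain carbon bound to an aromatic carbon, so that methyl becomes 3-fluorobenzyl. Within the data shown here, no measured pair isolates this change. Among the measured compounds shown here, the nearest guide is compound 3 at 20% as the only measured compound with a fluorinated benzyl group, although it also differs from compound 4 elsewhere. In this assay a fall in growth inhibition is therefore expected, modestly beyond the scatter, and the estimated step is a number 13 percentage points lower from compound 1 to compound 4 (beyond the scatter) on that reading. For compound 4 the estimated value is 22% within an expected range from 8% to 38% on this read-out.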

Compound 4, percent growth inhibition at one concentration: 9%
Compound 4: the middle estimate sits 13 percentage points above what was measured; the range from low to high includes it.
By their numbers in this assay, from the lowest: compound 4; then compound 3; then compound 1; then compound 2.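

In this assay, among these compounds, 3-fluorophenyl in place of hydrogen on a saturated chain carbon bound to an aromatic carbon, which turns methyl into 3-fluorobenzyl, gives a number 26 percentage points lower from compound 1 to compound 4 (beyond the scatter) and is the only change so far read in isolation. The read-out therefore responds to what sits at this position, and with this larger group the number falls rather than rises, at least on the core of compound 1. Nothing available on the compounds bears on why the number moves in this direction.

The compounds shown do not separate the contribution of the ring from that of its fluorine, and a plain benzyl group would address that. From the compounds shown here alone, whether the fall continues or reverses with a longer chain such as propyl, or with an amine or a carboxylic acid at this carbon, also remains open.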